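The compounds below may be only part of what the source reports. "The series", "measured", "known", "first", "only" and "open" are said of these compounds alone.

Measured compounds in a functional assay on HL-60 cells (Homo sapiens) for antiproliferative activity, with a stated time of 72 h; on this read-out lower numbers stand for stronger inhibition of growth and higher numbers for weaker inhibition of growth:

compound 1 `C=C(CC)C(=O)c1ccc(OCC(=O)O)cc1C` — > 60000 nM, a limit of the assay.
compound 2 `C=C(CC)C(=O)c1ccc(OCC(=O)O)cc1Br` — > 60000 nM, a limit of the assay.
compound 3 `C=C(C)C(=O)c1ccc(OC(C)C(=O)O)cc1C` — > 60000 nM, a limit of the assay.

Each of the three values is a limit and not a number, so none of the compounds gives a readable concentration in this assay. The change from compound 1 to compound 2 is bromo in place of methyl on an aromatic carbon. Its step, a step that the two limits leave unreadable from compound 1 to compound 2, cannot be sized because of the limit of > 60000 nM in this assay, at which 3 of the 3 values shown sit. Compound 3 and compound 1 have the same atoms joined differently; the difference between the two cores is not broken down here.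

Compound 4 `C=C(C)C(=O)c1ccc(OC(C)C(=O)O)cc1Br` has not yet been measured in this assay. It differs from compound 3 by bromo in place of methyl on an aromatic carbon. This is the same kind of change as that from compound 1 to compound 2, but the surroundings differ: in compound 4 the place is ortho to a (1-methylethenyl)carbonyl group and meta to a 1-carboxyethoxy group, whereas in compound 2 it is ortho to a group of 6 heavy atoms and meta to a carboxymethoxy group.

Since compound 3 sits at the limit and the earlier step of the same kind is unreadable, the step from compound 3 to compound 4 is expected to be a step that the limit leaves unreadable from compound 3 to compound 4, i.e. no readable change, resting on the limit shown for compound 3. Compound 4 is accordingly expected to give about 80000 nM in this assay, most likely again reported only as a limit, within 30000 nM to 250000 nM.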

Compound 4, concentration for 50% growth inhibition: > 60000 nM
Compound 4 was reported as a limit; the forecaster's own chance of this, stated with the estimate: 85%; the middle value lies beyond the limit too.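

In this assay compound 4 gives > 60000 nM, a limit of the assay and not a number. Bromo in place of methyl therefore yields no readable step between compound 3 and compound 4, because every value remains at the same limit: the limit of > 60000 nM in this assay, at which 4 of the 4 values shown sit.

The compounds shown leave open whether any of the changes among them alters growth inhibition, and at what concentration any of them would inhibit growth.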